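Sulfur substituent variation on the shared pyrazolopyrimidine-like core

This account rests on a few compounds, and the source may have more. Where it says the series, first, only, none or still open, it means among the compounds named here.

Compound 1 `CC(C)c1n[nH]c2c(NCc3ccc(-c4ccccn4)cc3)nc(SCC3CNC(=O)O3)nc12` gives 80 nM in a functional assay on HT cells (Homo sapiens) for antiproliferative activity, read by fluorescence, with a stated time of 72 h; a lower number here means a stronger inhibitor of growth, a higher number a weaker inhibitor of growth. Compound 2 `CC(C)c1n[nH]c2c(NCc3ccc(-c4ccccn4)cc3)nc(SC3CCCCC3O)nc12` gives 636 nM and compound 3 `CC(C)c1n[nH]c2c(NCc3ccc(-c4ccccn4)cc3)nc(SC3CCCC3O)nc12` gives 567 nM in this assay. Compound 3 therefore stands second highest of the three numbers: its nearest neighbour is compound 2, with a 1.1-fold lower number from compound 2 to compound 3 (0.05 log units; within the scatter) within the scatter, and its furthest is compound 1, with a 7.1-fold higher number from compound 1 to compound 3 (0.85 log units; beyond the scatter) beyond it.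

Compound 4 `CC(C)c1n[nH]c2c(NCc3ccc(-c4ccccn4)cc3)nc(SCCn3ccnc3)nc12` differs from compound 3 on the sulfur whose other neighbour is an aromatic carbon: 2-(1H-imidazol-1-yl)ethyl in place of 2-hydroxycyclopentyl on a sulfur. The hydroxy-bearing ring with its one hydrogen-bond donor leaves and a chain carrying a five-membered aromatic ring with two hetero atoms and no donor enters. Among the measured compounds shown here, the steps that bear on this are an 8.0-fold higher number from compound 1 to compound 2 (0.90 log units; beyond the scatter) and a 7.1-fold higher number from compound 1 to compound 3 (0.85 log units; beyond the scatter), both showing that a 2-hydroxycycloalkyl group reads weaker than a ring linked through a chain, while a 1.1-fold lower number from compound 2 to compound 3 (0.05 log units; within the scatter) shows the two hydroxycycloalkyl groups as interchangeable. Returning to a chain-linked heterocycle, compound 4 is expected to move toward compound 1 in this assay, a step of a 2.6-fold lower number from compound 3 to compound 4 (0.41 log units; beyond the scatter). The estimate for compound 4 is 220 nM, within 60 nM to 900 nM.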

Compound 4, concentration for 50% growth inhibition: 155 nM
Compound 4: middle estimate off by 1.4-fold (0.15 log units), on the high side; low and high end bracket the measured number.
By their numbers in this assay, from the lowest: compounds 1 and 4 (each within the scatter of the next); then compounds 3 and 2 (each within the scatter of the next).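

In this assay, 2-(1H-imidazol-1-yl)ethyl on the sulfur reads stronger than either hydroxycycloalkyl group, with a 3.7-fold lower number from compound 3 to compound 4 (0.56 log units; beyond the scatter) and a 4.1-fold lower number from compound 2 to compound 4 (0.61 log units; beyond the scatter) as the two steps. The low number at this position is therefore not confined to the ring of compound 1, since a 1.9-fold higher number from compound 1 to compound 4 (0.29 log units; within the scatter) leaves compound 1 and compound 4 level and the entering group has 0 hydrogen-bond donors. Nothing available explains these steps.

Still open, as far as these compounds go, is whether the imidazole ring or the chain carries the gain, which a 2-aminoethyl group or a 3-(1H-imidazol-1-yl)propyl chain on the same sulfur would help separate. Also open, from the compounds shown here alone, is how an open-chain 2-hydroxyethyl group or a carboxylic acid on the chain would read against the hydroxycycloalkyl groups.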